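Swapping an Ether Link for an Amine Link

A few compounds are considered here, and "the series" means these few. Any claim that something is new, unique, unknown or untested is made for them only; others in the source may bear on it.

Compound 1, `Nc1cc(N)c2nc(-c3ccccc3)c(Oc3ccc(F)cc3)nc2c1`, is one of two compounds tested in a functional assay on HOP-62 cells (Homo sapiens) for inhibition, read by sulforhodamine B assay, with a stated time of 48 h; on this read-out lower numbers stand for stronger inhibition of growth and higher numbers for weaker inhibition of growth. In this assay compound 1 gives 49000 nM. The other compound, compound 2, `COc1cc(CNc2nc3cc(N)cc(N)c3nc2-c2ccccc2)cc(OC)c1OC`, reaches only a limit of the assay rather than a number: in this assay compound 2 shows < 50200 nM. Within the data shown here, since (the limit of < 50200 nM in this assay, at which 1 of the 2 values shown sits), compound 1 holds the only plain number here, so its standing among the others cannot be judged.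

Compound 3, `Nc1cc(N)c2nc(-c3ccccc3)c(NCc3ccc(F)cc3)nc2c1`, differs from compound 1 in a single place: (4-fluorobenzyl)amino in place of 4-fluorophenoxy on an aromatic carbon. Among the measured compounds shown here, no pair of measured compounds shows the effect of this exchange, so the step has to be guessed. The expectation is a shift no larger than the usual scatter, without a clear direction. Compound 3 is therefore estimated to give about 40000 nM in this assay, with a likely range from 15000 nM to 100000 nM. That estimate corresponds to an expected step of a 1.2-fold lower number from compound 1 to compound 3 (0.09 log units; within the scatter).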

Compound 3, concentration for total growth inhibition: < 100000 nM
Compound 3: only a limit was reported; the forecaster's own chance of this, stated with the estimate: 30%; the middle value is on the limit's open side.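

In this assay compound 3 gives < 100000 nM, which is a limit of the assay and not a number, so no step can be read between compound 1 and compound 3. As far as these compounds go, whether (4-fluorobenzyl)amino in place of 4-fluorophenoxy changes growth inhibition at all, and in which direction, stays open.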